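Configuration at a ring carbon: compound 3 to compound 4

The source may hold more compounds than are shown below. What is called first, only, known or untested is meant among the compounds shown, and "the series" means these compounds.

Measured in a functional assay on QGY cells (Homo sapiens) for cytotoxicity, read by MTT assay, with a stated time of 48 h; a higher number here means a weaker inhibitor, a lower number a stronger inhibitor:
- compound 1 `COc1cc([C@@H]2C[C@@]2(CO)C(=O)Nc2ccccc2)cc(OC)c1OC`: 36700 nM
- compound 2 `COc1cc([C@H]2C[C@]2(CO)C(=O)Nc2ccccc2Cl)cc(OC)c1OC`: 40700 nM
- compound 3 `COc1cc([C@H]2C[C@@]2(CO)C(=O)Nc2ccccc2Cl)cc(OC)c1OC`: > 100000 nM

Compound 3 gives only a limit, > 100000 nM, and no number. Compound 4 `COc1cc([C@@H]2C[C@@]2(CO)C(=O)Nc2ccccc2Cl)cc(OC)c1OC` is not yet measured in this assay. Against compound 3: the two compounds have the same atoms and bonds and differ only in configuration as drawn: 1 of 2 stereo elements differ; a stereocentre at a saturated ring carbon is drawn R in compound 3 and S in compound 4.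

Among the measured compounds shown here, the one measured step of this kind is an at least 2.4-fold higher number from compound 2 to compound 3 (0.39 log units; beyond the scatter), and it too rests on (the fact that compounds 2 and 3 differ only in the configuration as drawn). Its size is a floor, not a number. A step of similar size in the opposite direction is therefore expected, toward a lower number. The expected step is an at least 2.2-fold lower number from compound 3 to compound 4 (0.34 log units; beyond the scatter). For compound 4 the estimated value is 45000 nM, with an expected range of 15000 nM to 100000 nM.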

Compound 4, half-maximal inhibitory concentration: 24500 nM
For compound 4 the middle estimate is 1.8-fold (0.26 log units) above the measured one; the range from low to high includes it.
By their numbers in this assay, from the lowest: compounds 4, 1 and 2 (each within the scatter of the next). At a limit, above all of these: compound 3.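

Inverting this ring carbon alone gives an at least 4.0-fold lower number from compound 3 to compound 4 (0.61 log units; beyond the scatter) in this assay; compound 3 stands at a limit, so this step is a floor. Inverting both stereocentres gives a 1.7-fold lower number from compound 2 to compound 4 (0.22 log units; within the scatter), so the mirror-image pair is not separated, while each of the two is separated from compound 3. Chloro in place of hydrogen gives a 1.5-fold lower number from compound 1 to compound 4 (0.18 log units; within the scatter), also within the scatter.

The compounds shown leave open how an amine in place of chloro would read. They also leave open the effect of a carboxylic acid in place of the hydroxymethyl.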